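Moving the fluorine on the aryl piperazine amide

The compounds below may be only part of what the source reports. "The series", "measured", "known", "first", "only" and "open" are said of these compounds alone.

Compound 1 `CC(C(=O)N1CCN(c2ccc(Cl)cc2)CC1)N1C(=O)CCC1=O`, compound 2 `CCC(C(=O)N1CCN(c2cccc(F)c2)CC1)N1C(=O)CCC1=O` and compound 3 `CC(C(=O)N1CCN(c2ccccc2F)CC1)N1C(=O)CCC1=O` were tested in a functional assay on the whole organism (strain Swiss) with Mus musculus as the target, in the maximal electroshock model, with a stated time of 1 h, at a dose of 300 mg/kg by the intraperitoneal route; a lower number here means a weaker effect, a higher number a stronger effect of the compound at the dose given. Compound 1 gives 0%, compound 2 gives 75% and compound 3 gives 50%. Compound 3 thus sits in the middle: compound 2 is higher and compound 1 lower, both beyond the scatter.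

Compound 4 `CC(C(=O)N1CCN(c2ccc(F)cc2)CC1)N1C(=O)CCC1=O` is not yet measured. It differs from compound 3 in one place: 4-fluorophenyl in place of 2-fluorophenyl on an amine nitrogen in a ring. For the measured compounds named here, the only step that bears on this is a number 50 percentage points higher from compound 1 to compound 3 (beyond the scatter), which shows the ring position of a halogen mattering greatly. A return to the 4-position is therefore expected to cost activity, giving an expected step of a number 25 percentage points lower from compound 3 to compound 4 (beyond the scatter). Compound 4 is estimated at 25%, likely between 0% and 50%.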

Compound 4, a percentage reported as activity, at one dose (the size of the read-out at that dose, not a potency): 25%
Compound 4: middle estimate and measured number agree at the digits printed; measured number inside the range.
By their numbers in this assay, from the lowest: compound 1; then compound 4; then compound 3; then compound 2.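

With the halogen kept as fluorine, moving it alone matters in this assay: there is a number 25 percentage points lower from compound 3 to compound 4 (beyond the scatter). The halogen itself also matters with the ring position unchanged, since 4-fluorophenyl in place of 4-chlorophenyl gives a number 25 percentage points higher from compound 1 to compound 4 (beyond the scatter) and so separates two changes that were combined in the earlier step. Nothing measured here explains either step. The compounds shown leave open how a methoxy or trifluoromethyl group on the phenyl ring would compare. Compound 2 differs from compound 3 in two places, so the contributions of its chain and its fluorine remain unseparated.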